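The source may report more compounds than this note shows. Statements on the series, on what has been measured and on what is new or still open speak of the compounds shown alone.

Of the compounds shown here, two have so far been measured in a physicochemical assay for lipophilicity, at pH 7.4; a higher number here means a more lipophilic compound, a lower number a more polar compound. Compound 1 `Cc1cc(Nc2ccc(C(F)(F)F)cc2)n2nc(C3CC3)nc2n1` gives 3.3. Compound 2 `COCCc1nc2nc(C)cc(Nc3ccc(S(F)(F)(F)(F)F)cc3)n2n1` gives 3, and these two numbers lie within the usual scatter of each other, so neither stands apart. Compound 3 `COCCc1nc2nc(C)cc(Nc3ccc(C(F)(F)F)cc3)n2n1` has not yet been measured. It differs from compound 2 in a single place: a group of 4 heavy atoms (1 carbon, 3 fluorine; no ring) in place of a group of 6 heavy atoms (5 fluorine, 1 sulfur; no ring), on an aromatic carbon. Within the data shown here, no pair of measured compounds shows this change on its own, so its size is not known from the data at hand. A small step downward in this assay is expected, about a number 0.30 log units lower from compound 2 to compound 3 (within the scatter), near the edge of the scatter. Compound 3 is estimated at 2.7, with a likely range from 2.3 to 3.1.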

Compound 3, distribution coefficient: 2.7
Beside the measured number, compound 3's estimate shows no gap at the digits printed; the measured number falls inside the stated range.
By their numbers in this assay, from the lowest: compounds 3, 2 and 1 (each within the scatter of the next, the first and the last beyond it).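

Putting trifluoromethyl on the aromatic carbon in place of the group of 6 heavy atoms gives a number 0.30 log units lower from compound 2 to compound 3 (within the scatter) in this assay, so the two groups cannot be told apart here. Among these compounds, at the other position, 2-methoxyethyl in place of cyclopropyl gives a number 0.60 log units lower from compound 1 to compound 3 (beyond the scatter), the only step here beyond the scatter. Nothing at hand explains either step.

As far as these compounds go, each change is seen in a single pair, so it is unknown whether either step would hold on another partner. From the compounds shown here alone, how a nitrile on the aromatic carbon, or an amine in place of 2-methoxyethyl, would compare remains open.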